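Butyl for isopropyl on the amine nitrogen of an aryltriazene

The compounds below may be only part of what the source reports. "The series", "measured", "known", "first", "only" and "open" are said of these compounds alone.

Measured compounds:
Compound 1, `CN(C)/N=N/c1ccc([N+](=O)[O-])cc1C(N)=O`, in a functional assay on L1210 cells (Mus musculus) for antiproliferative activity (a lower number here means a less potent compound, a higher number a more potent compound, by a factor of ten per unit of this negative logarithm), gives 3.26.
Compound 2, `CC(C)N(C)/N=N/c1ccc(C(N)=O)cc1`, in this assay gives 3.17.
Compound 3, `CN(C)/N=N/c1c(Cl)cc(Cl)cc1C(N)=O`, in this assay gives 3.14.

The three numbers in this assay sit close together. Compound 2 holds the second highest of them, but its gap to compound 3 and its gap to compound 1 both fall within the usual scatter of repeated measurements, so none of the three can be set apart from the others on this evidence.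

The next compound, compound 4, `CCCCN(C)/N=N/c1ccc(C(N)=O)cc1`, differs from compound 2 in one place: butyl in place of isopropyl on an amine nitrogen. Going by the values given here, no pair of measured compounds differs in a single place, so no measured step guides this change directly. What the three measured compounds do show is that shifts in the groups on the core and on the amine nitrogen have left this assay almost unmoved. On that basis compound 4 is expected to stay near compound 2, with the step of a number 0.08 log units higher from compound 2 to compound 4 (within the scatter) estimated as one that does not go beyond the scatter in either direction. For compound 4 the estimate in this assay is 3.25, in a range from 2.85 to 3.65.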

Compound 4, logarithm of the reciprocal of the active concentration, log(1/C): 3.47
Estimate against measurement, compound 4: 0.22 log units below; measured number inside the range.
By their numbers in this assay, from the lowest: compounds 3, 2, 1 and 4 (each within the scatter of the next, the first and the last beyond it).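

Going by these compounds alone, the pair of compound 2 and compound 4 gives the first single-place step in this set: in this assay, butyl in place of isopropyl on the amine nitrogen, with the shared core and the other neighbours of that nitrogen unchanged, gives a number 0.30 log units higher from compound 2 to compound 4 (within the scatter). Going from a group of 3 carbon atoms to one of 4, neither carrying a hydrogen-bond donor, a hydrogen-bond acceptor, a ring or a net charge, therefore does not separate the two compounds on this evidence, although a single step cannot show how this position would respond to other groups. Nothing available bears on why the step has this size.

A single step cannot show whether a hexyl or octyl chain, a cyclohexyl ring, or a chain ending in a hydroxyl group or an amine at this nitrogen would stay as close to compound 2 or move beyond the scatter. It also leaves open whether butyl in place of methyl on the amine nitrogen would behave in the same way on the core of compound 1 or the core of compound 3.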